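A few compounds are considered here, and "the series" means these few. Any claim that something is new, unique, unknown or untested is made for them only; others in the source may bear on it.

Among the compounds with values here, compound 2, with the structure `COc1cc(N(Cc2nc3ccccc3[nH]2)C(=O)c2ccc(C)cc2)cc(OC)c1OC`, is the only member of this small set that gives a number in a functional assay on MGC-803 cells (Homo sapiens) for inhibition, read by MTT assay, with a stated time of 48 h (a lower number here means a stronger inhibitor, a higher number a weaker inhibitor), where compound 2 gives 30500 nM. Its neighbour compound 1, `COc1cc(N(Cc2nc3ccccc3[nH]2)C(=O)c2cccc(Cl)c2)cc(OC)c1OC`, differs from it by carrying a 3-chlorophenyl in place of the 4-methylphenyl on the carbonyl carbon. In this assay compound 1 reaches only a limit, > 50000 nM, which is the limit that (the limit of > 50000 nM in this assay, at which 1 of the 2 values shown sits). Within the data shown here, the one measured step therefore runs an at least 1.6-fold lower number from compound 1 to compound 2 (0.21 log units; that floor lies within the scatter), and it sets only a floor, one that itself lies within the scatter.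

The unmeasured compound 3, `COc1ccc(C(=O)N(Cc2nc3ccccc3[nH]2)c2cc(OC)c(OC)c(OC)c2)cc1OC`, takes the next step on the same carbonyl carbon: 3,4-dimethoxyphenyl in place of 4-methylphenyl on a carbonyl carbon. Among the measured compounds shown here, the single measured step bears on it only loosely, since it concerns a different exchange on that carbon and its size is not fixed beyond a floor. For the measured compounds named here, no step in this set shows more than a change near the scatter, so a large move in this assay is not expected in either direction. Compound 3 is estimated at 20000 nM, between 5000 nM and 60000 nM, a step of a 1.5-fold lower number from compound 2 to compound 3 (0.18 log units; within the scatter) that is expected to stay close to the scatter.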

Compound 3, half-maximal inhibitory concentration: 22400 nM
For compound 3 the middle estimate is 1.1-fold (0.05 log units) below the measured one; the measured number falls inside the stated range.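

In this assay, 3,4-dimethoxyphenyl on the carbonyl carbon gives a 1.4-fold lower number from compound 2 to compound 3 (0.13 log units; within the scatter), so compound 2 and compound 3 cannot be told apart, although the entering group has more heavy atoms and brings hydrogen-bond acceptors that 4-methylphenyl lacks. Within the data shown here, the exchange of 3-chlorophenyl for 3,4-dimethoxyphenyl on the same carbon gives an at least 2.2-fold lower number from compound 1 to compound 3 (0.34 log units; beyond the scatter), the first step at this position that clears the scatter, which the earlier pair could not show. That step fixes only a floor and not a size, because compound 1 stands at a limit of the assay and not at a number: the limit of > 50000 nM in this assay, at which 1 of the 3 values shown sits.

The compounds shown leave open how this carbonyl position would respond to a phenyl ring carrying an amine or a carboxylic acid, and whether any group there would move the number far from those of compound 2 and compound 3. They also cannot separate the contributions of the two methoxy groups, since neither 3-methoxyphenyl nor 4-methoxyphenyl stands among them.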